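From compound 3 to compound 4: one ring group exchanged

This account rests on a few compounds, and the source may have more. Where it says the series, first, only, none or still open, it means among the compounds named here.

Measured in a functional assay (aorta) with Rattus norvegicus as the target, in the presence of a further agent that is not named here; a lower number here means that less compound is needed, a higher number that more compound is needed for the effect:
- Compound 1 `COC(=O)C1=C(C)N=C(C)/C(=C(/O)OC)C1c1ccccc1OCc1nonc1C(N)=O`: 970 nM
- Compound 2 `COC(=O)C1=C(C)N=C(C)/C(=C(/O)OC)C1c1ccccc1OCc1no[n+]([O-])c1C(N)=O`: 550 nM
- Compound 3 `COC(=O)C1=C(C)N=C(C)/C(=C(/O)OC)C1c1ccccc1OCc1nonc1C#N`: 6.6 nM

Of the three compounds measured in this assay, compound 3 has the lowest number, 6.6 nM. The next step leads to compound 4 `COC(=O)C1=C(C)N=C(C)/C(=C(/O)OC)C1c1ccccc1OCc1no[n+]([O-])c1C#N`, in which the 4-cyano-1,2,5-oxadiazol-3-yl group is exchanged: a group of 8 heavy atoms (3 carbon, 3 nitrogen, 2 oxygen; one five-membered aromatic ring with 3 hetero atoms) in place of a group of 7 heavy atoms (3 carbon, 3 nitrogen, 1 oxygen; one five-membered aromatic ring with 3 hetero atoms), on a saturated chain carbon bound to an oxygen on an aromatic ring. For the measured compounds named here, the closest precedent for this ring change is a 1.8-fold lower number from compound 1 to compound 2 (0.25 log units; within the scatter), where the ring carries carbamoyl rather than cyano. That step stays within the scatter. The large steps of a 150-fold lower number from compound 1 to compound 3 (2.17 log units; beyond the scatter) and an 83-fold lower number from compound 2 to compound 3 (1.92 log units; beyond the scatter) both involve the exchange of carbamoyl for cyano, which is not part of the present change, so they say little about its size. Going by the values given here, no measured pair shows the ring change with cyano in place. Only a small shift toward a lower number is therefore expected, and the expected step, a 1.3-fold lower number from compound 3 to compound 4 (0.12 log units; within the scatter), does not go beyond the scatter. The estimate for compound 4 is 5 nM, with an expected range from 1.5 nM to 18 nM.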

Compound 4, half-maximal effective concentration: 4.4 nM
For compound 4 the middle estimate is 1.1-fold (0.06 log units) above the measured one; the measured number falls inside the stated range.
By their numbers in this assay, from the lowest: compounds 4 and 3 (each within the scatter of the next); then compounds 2 and 1 (each within the scatter of the next).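

In this assay, the ring exchange, now read with cyano on the ring, gives a 1.5-fold lower number from compound 3 to compound 4 (0.18 log units; within the scatter), so with cyano as with carbamoyl it stays within the scatter. The exchange of carbamoyl for cyano can now be read on the second ring as well, as a 130-fold lower number from compound 2 to compound 4 (2.10 log units; beyond the scatter), and the two changes together give a 220-fold lower number from compound 1 to compound 4 (2.34 log units; beyond the scatter). The large effect of the cyano group at this aromatic carbon is therefore not confined to one of the two rings: the same change on two cores in this assay, a 150-fold lower number (2.17 log units; beyond the scatter) from compound 1 to compound 3 and a 130-fold lower number (2.10 log units; beyond the scatter) from compound 2 to compound 4, 1.2-fold (0.07 log units) apart, within the scatter of two such steps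

Going by these compounds, what a carboxylic acid or an amine on this aromatic carbon would give remains open, as does the effect of a longer chain in place of the saturated chain carbon bound to an oxygen on an aromatic ring. Also open, on these data alone, is whether the ring exchange would stay within the scatter with such groups in place.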